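The compounds below may be only part of what the source reports. "The series", "measured", "known", "first", "only" and "open" are said of these compounds alone.

Measured compounds in a functional assay on MCF7 cells (Homo sapiens) for inhibition, read by sulforhodamine B assay; a higher number here means a weaker inhibitor, a lower number a stronger inhibitor:

Compound 1 `O=C1C(Nc2cccc(Cl)c2)=CC(=O)c2c1nc1n2[C@H]2OC[C@@H](O)[C@H]2OC1` gives 2970 nM.
Compound 2 `O=C1C(NC2CCCC2)=CC(=O)c2c1nc1n2[C@H]2OC[C@@H](O)[C@H]2OC1` gives only a limit, > 16000 nM.
Compound 3 `O=C1C(Nc2ccccc2)=CC(=O)c2c1nc1n2[C@H]2OC[C@@H](O)[C@H]2OC1` gives only a limit, > 4000 nM.

Compound 3 therefore stands on no number of its own, only on a limit (the limit of > 4000 nM in this assay, at which 1 of the 3 values shown sits); compound 2 stands on a limit as well (the limit of > 16000 nM in this assay, at which 1 of the 3 values shown sits). For the measured compounds named here, the one readable number in the set belongs to compound 1. The step from compound 1 to compound 3, hydrogen in place of chloro on an aromatic carbon, is an at least 1.3-fold higher number from compound 1 to compound 3 (0.12 log units; that floor lies within the scatter); the step to the cyclopentyl amine is an at least 5.3-fold higher number from compound 1 to compound 2 (0.73 log units; beyond the scatter); the step from compound 2 to compound 3 is a step that the two limits leave unreadable from compound 2 to compound 3.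

Compound 4 `O=C1C(Nc2ccc(I)cc2)=CC(=O)c2c1nc1n2[C@H]2OC[C@@H](O)[C@H]2OC1` differs from compound 3 by iodo in place of hydrogen on an aromatic carbon, placed para to a large group. The nearest guide is the step from compound 1 to compound 3, an at least 1.3-fold higher number from compound 1 to compound 3 (0.12 log units; that floor lies within the scatter), read backwards. Compound 4 is expected to stand near compound 1, or somewhat lower. For compound 4 a step of an at least 1.6-fold lower number from compound 3 to compound 4 (0.20 log units; that floor lies within the scatter) is expected in this assay, giving an estimate of 2500 nM with a range from 800 nM to 8000 nM.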

Compound 4, half-maximal inhibitory concentration: 3890 nM
The estimate for compound 4 lay 1.6-fold (0.19 log units) below the measured number; low and high end bracket the measured number.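

In this assay, the 4-iodophenyl group gives the series a second readable number on an aryl amine, and it cannot be told apart from the 3-chlorophenyl group: a 1.3-fold higher number from compound 1 to compound 4 (0.12 log units; within the scatter). Against the cyclopentyl amine, which stands only on a limit, the separation is beyond the scatter, so compound 2 now falls behind two halogen-bearing aryl amines: an at least 4.1-fold lower number from compound 2 to compound 4 (0.61 log units; beyond the scatter). Iodo in place of hydrogen, para to a large group, gives an at least 1.0-fold lower number from compound 3 to compound 4 (0.01 log units; that floor lies within the scatter), and no true size can be read from that step because compound 3 stands on a limit: the limit of > 4000 nM in this assay, at which 1 of the 4 values shown sits.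

Still open, from the compounds shown here alone, is whether a halogen matters at all on the phenyl ring. A methoxy group or a carboxylic acid at the same place, or a 4-chlorophenyl group, would separate the kind of group from its place.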